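A Dimethoxyphenyl Swap Awaiting Its Antiproliferative Reading

The source may report more compounds than this note shows. Statements on the series, on what has been measured and on what is new or still open speak of the compounds shown alone.

Compound 1 `COc1cc(O)c(C(=O)/C=C/c2cc(Cl)cc(Cl)c2)c(OC)c1`: 1900 nM
Compound 2 `COc1cc(OC)c(C(=O)/C=C/c2ccc(OC)c(OC)c2)c(OCC=C(C)C)c1`: 5700 nM

In a functional assay on HCT-116 cells (Homo sapiens) for antiproliferative activity, read by sulforhodamine B assay, with a stated time of 48 h (on this read-out lower numbers stand for stronger inhibition and higher numbers for weaker inhibition), compound 2 has the higher of the two numbers at 5700 nM, while compound 1 gives 1900 nM, a gap beyond the scatter. Compound 3 `COc1cc(OC)c(C(=O)/C=C/c2cccc(OC)c2OC)c(OCC=C(C)C)c1` has the same atoms as compound 2, joined differently: 2,3-dimethoxyphenyl in place of 3,4-dimethoxyphenyl on a double-bonded chain carbon bound to a double-bonded chain carbon. Going by the values given here, no measured pair shows this kind of change, so the expectation in this assay is modest, with no shift beyond the scatter in either direction. The estimated step is a 1.1-fold lower number from compound 2 to compound 3 (0.06 log units; within the scatter). The expected value for compound 3 is 5000 nM, within an estimated range of 1800 nM to 14000 nM.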

Compound 3, half-maximal inhibitory concentration: 11700 nM
Beside the measured number, compound 3's estimate is 2.3-fold (0.37 log units) below it; the measured number falls inside the stated range.
By their numbers in this assay, from the lowest: compound 1; then compound 2; then compound 3.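

In this assay putting 2,3-dimethoxyphenyl in place of 3,4-dimethoxyphenyl gives a 2.1-fold higher number from compound 2 to compound 3 (0.31 log units; beyond the scatter) and so shows that, on this double-bonded chain carbon, the arrangement of the two methoxy groups alone changes the reading while the atoms stay the same. Going by these compounds alone, no earlier pair had isolated a single change at this place. Nothing measured here accounts for the shift. From the compounds shown here alone, whether an amine or a carboxylic acid on the phenyl ring at this place would lower or raise the number remains open.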